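A few compounds are considered here, and "the series" means these few. Any claim that something is new, unique, unknown or untested is made for them only; others in the source may bear on it.

Compound 1, `FC(F)(F)c1cccc(NC(=S)Nc2cccc(Br)c2)c1`, gives 10000 nM in an ADME assay on BHK cells (Mesocricetus auratus) for cytotoxicity, read by MTT assay, with a stated time of 96 h; a lower number here means that less compound is tolerated, a higher number that more compound is tolerated.
Compound 2, `FC(F)(F)c1cccc(NC(=S)Nc2ccc(Cl)cc2)c1`, gives 10000 nM in this assay.
Compound 3, `O=[N+]([O-])c1ccc(NC(=S)Nc2cccc(C(F)(F)F)c2)cc1`, gives 9500 nM in this assay.

Compound 1 stands level with compound 2, and all three numbers lie within the scatter of one another; the step of no change at the digits printed from compound 1 to compound 2 (within the scatter) and the step of a 1.1-fold lower number from compound 2 to compound 3 (0.02 log units; within the scatter) both show nothing beyond that scatter. Compound 4, `Fc1ccc(NC(=S)Nc2cccc(C(F)(F)F)c2)cc1`, is not yet measured. It differs from compound 1 in one place: 4-fluorophenyl in place of 3-bromophenyl on an amide-type nitrogen. The step that bears most directly on this is the exchange of one halophenyl group for another on the same nitrogen, no change at the digits printed from compound 1 to compound 2 (within the scatter), which left the number unchanged. The second step, a 1.1-fold lower number from compound 2 to compound 3 (0.02 log units; within the scatter), changed a substituent on that ring and also stayed within the scatter. No change beyond the scatter is therefore expected for compound 4, a step of no change at the digits printed from compound 1 to compound 4 (within the scatter), giving an estimate of 10000 nM with a range from 5000 nM to 20000 nM.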

Compound 4, half-maximal cytotoxic concentration: 26000 nM
Compound 4: the middle estimate sits 2.6-fold (0.41 log units) below what was measured, outside the stated range (above it).
By their numbers in this assay, from the lowest: compounds 3, 1 and 2 (each within the scatter of the next); then compound 4.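

In this assay the group on this nitrogen can shift the number beyond the scatter after all, as 4-fluorophenyl in place of 3-bromophenyl shows (a 2.6-fold higher number from compound 1 to compound 4 (0.41 log units; beyond the scatter)). The same holds for fluoro in place of chloro (a 2.6-fold higher number from compound 2 to compound 4 (0.41 log units; beyond the scatter)) and for fluoro in place of nitro (a 2.7-fold higher number from compound 3 to compound 4 (0.44 log units; beyond the scatter)), so compound 4 stands apart from the other three. No measurement shown gives a reason for this rise.

Still open, as far as these compounds go, is whether the fluoro group or its ring position matters, which a 3-fluorophenyl group could separate. From the compounds shown here alone, the effect of an amine or a methoxy group on this ring also remains unknown.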